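Methoxy to hydroxy on a shared core: cytotoxicity outlook

The compounds below may be only part of what the source reports. "The series", "measured", "known", "first", "only" and "open" are said of these compounds alone.

Compound 1 `Nc1ncnc2c1ccn2COCCO`: in a functional assay on BSC-1 cells (Cercopithecidae) for cytotoxicity (a lower number here means a stronger inhibitor, a higher number a weaker inhibitor), compound 1 gives > 100000 nM, which is a limit of the assay rather than a number.
Compound 2 `CS(=O)(=O)c1nc(N)c2ccn(COCCO)c2n1`: in this assay compound 2 gives > 100000 nM, again a limit.
Compound 3 `COc1nc(N)c2ccn(COCCO)c2n1`: in this assay compound 3 gives > 100000 nM, also a limit.

All three measured compounds sit at the same limit (the limit of > 100000 nM in this assay, at which 3 of the 3 values shown sit), so compound 3 cannot be told apart from compound 1 or compound 2 on the numbers shown. For the same reason the three measured steps are unreadable: a step that the two limits leave unreadable from compound 1 to compound 2, a step that the two limits leave unreadable from compound 1 to compound 3 and a step that the two limits leave unreadable from compound 2 to compound 3. They show only that neither methylsulfonyl nor methoxy on the aromatic carbon moved the value into the range the assay can report.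

Compound 4 `Nc1nc(O)nc2c1ccn2COCCO` differs from compound 3 by hydrogen in place of methyl on an oxygen on an aromatic ring. Going by the values given here, none of the measured steps bears directly on this change, and none of them gives a readable size to build on. What they do give is the same picture for every measured compound: a compound of this core at the limit. The expected step from compound 3 to compound 4 is therefore a step that the limit leaves unreadable from compound 3 to compound 4, meaning no movement beyond the scatter is expected. Compound 4 is estimated at 150000 nM in this assay, with a range from 50000 nM to 500000 nM, and most likely the assay will again report only a limit.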

Compound 4, half-maximal inhibitory concentration: > 100000 nM
Compound 4 gave a limit, no number (the forecaster's own chance of this, stated with the estimate: 85%); the middle value lies beyond the limit too.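

In this assay compound 4 gives > 100000 nM as a limit rather than a number. Going by these compounds alone, no step linking compound 4 to compound 1, compound 2 or compound 3 can be read, as all four compounds share one limit: the limit of > 100000 nM in this assay, at which 4 of the 4 values shown sit. As far as these compounds go, whether these four compounds differ at all in this assay remains open, as does which change to the shared core, if any, would give a readable value.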